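This account rests on a few compounds, and the source may have more. Where it says the series, first, only, none or still open, it means among the compounds named here.

Compound 1 `COc1cc(-c2cc(/C=C/C(=O)c3ccc(N)cc3)[nH]n2)cc(OC)c1OC`, compound 2 `COc1ccc(C(=O)/C=C/c2cc(-c3cc(OC)c(OC)c(OC)c3)n[nH]2)cc1OC` and compound 3 `COc1ccc(C(=O)/C=C/c2cc(-c3cc(OC)c(OC)c(OC)c3)n[nH]2)cc1` were tested in a functional assay on NCI-H460 cells (Homo sapiens) for inhibition, read by sulforhodamine B assay, with a stated time of 48 h; a higher number here means that more compound is tolerated, a lower number that less compound is tolerated. Compound 1 gives 44800 nM, compound 2 gives 7860 nM and compound 3 gives 8180 nM. The cores of compound 1 and compound 2 differ by 4-aminophenyl in place of 3,4-dimethoxyphenyl on a carbonyl carbon, and that change brought a 5.7-fold lower number from compound 1 to compound 2 (0.76 log units; beyond the scatter). Within the core of compound 2, the change hydrogen in place of methoxy on an aromatic carbon made a 1.0-fold higher number from compound 2 to compound 3 (0.02 log units; within the scatter). Compound 4 `COc1ccc(-c2cc(/C=C/C(=O)c3ccc(N)cc3)[nH]n2)cc1OC`, not yet measured, carries the same kind of change on compound 1: hydrogen in place of methoxy on an aromatic carbon. The surroundings differ slightly, since in compound 1 the place is also meta to a methoxy group, whereas in compound 2 it is not. Because a 1.0-fold higher number from compound 2 to compound 3 (0.02 log units; within the scatter) lay within the scatter, a similarly small step is expected here, a 1.0-fold lower number from compound 1 to compound 4 (0.01 log units; within the scatter). Compound 4 is therefore estimated at 44000 nM in this assay, between 18000 nM and 110000 nM.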

Compound 4, concentration lethal to 50% of the cells: 10600 nM
Estimate against measurement, compound 4: 4.2-fold (0.62 log units) above; measured number below the stated range.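

In this assay, putting hydrogen in place of methoxy on an aromatic carbon gave a 4.2-fold lower number from compound 1 to compound 4 (0.63 log units; beyond the scatter), so the change did not carry over from one core to the other with the same effect: the same change on two cores in this assay, a 1.0-fold higher number (0.02 log units; within the scatter) from compound 2 to compound 3 and a 4.2-fold lower number (0.63 log units; beyond the scatter) from compound 1 to compound 4, 4.4-fold (0.64 log units) apart, beyond the scatter of two such steps

A near-silent result on one core therefore gives no safe forecast for the same change on another core in this series. For the compounds shown here, with only two such steps, this shows that the effect can depend on its surroundings, but it does not show which structural difference is responsible or how the change would behave on a third core.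

The compounds shown leave open how a hydroxyl group or a chlorine atom would compare with methoxy and hydrogen at this place on the core of compound 1.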